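Swapping the aryl group on the ring nitrogen: compound 4

This account rests on a few compounds, and the source may have more. Where it says the series, first, only, none or still open, it means among the compounds named here.

Measured so far, in a functional assay on Hep 3B2 cells (Homo sapiens) for inhibition, read by sulforhodamine B assay, with a stated time of 72 h; on this read-out lower numbers stand for stronger inhibition and higher numbers for weaker inhibition:
compound 1 `C[C@H](Nc1ncnc2[nH]cnc12)c1nn(-c2ccncc2)c2cc(F)ccc12` gives 21400 nM
compound 2 `C[C@H](Nc1ncnc2[nH]cnc12)c1nn(-c2cccc(S(C)(=O)=O)c2)c2cc(F)ccc12` gives 13000 nM
compound 3 `C[C@H](Nc1nc(N)nc(N)c1C#N)c1nn(-c2cccc(S(C)(=O)=O)c2)c2cc(F)ccc12` gives 19700 nM

Among the measured compounds shown here, compound 2 has the lowest of the three numbers, but its gaps to compound 3 and to compound 1 both lie within the usual scatter, so no compound can be called stronger than another. Compound 4 `C[C@H](Nc1ncnc2[nH]cnc12)c1nn(-c2cc(F)cc(F)c2)c2cc(F)ccc12` keeps the core of compound 2 and differs only in the group on the ring nitrogen: 3,5-difluorophenyl in place of 3-(methylsulfonyl)phenyl on an aromatic nitrogen. For the measured compounds named here, the one measured step at this position, a 1.6-fold lower number from compound 1 to compound 2 (0.22 log units; within the scatter), was within the scatter, so changing this aryl group has so far left the read-out essentially unchanged. The step of a 1.2-fold higher number from compound 2 to compound 4 (0.06 log units; within the scatter) is therefore expected to stay within the scatter. In this assay compound 4 is estimated at 15000 nM, with a range from 5000 nM to 45000 nM.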

Compound 4, half-maximal inhibitory concentration: > 40000 nM
Compound 4: no number, only a limit (the forecaster's own chance of this, stated with the estimate: 15%); middle value at least 2.6-fold (0.42 log units) from the limit.
By their numbers in this assay, from the lowest: compounds 2, 3 and 1 (each within the scatter of the next). At a limit, above all of these: compound 4.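

Among the compounds shown here, the aryl group on the ring nitrogen can matter after all: this assay shows an at least 3.0-fold higher number from compound 2 to compound 4 (0.48 log units; beyond the scatter), the first step at this position to clear the scatter. Measured against the pyridin-4-yl group, the change is less clear: an at least 1.8-fold higher number from compound 1 to compound 4 (0.27 log units; that floor lies within the scatter). Compound 4 has no number, only a limit of the assay: the limit of > 40000 nM in this assay, at which 1 of the 4 values shown sits.

On these data alone, whether the step follows from losing the methylsulfonyl group or from gaining the two fluorine atoms remains open. A phenyl ring carrying a single fluorine, an amine or a carboxylic acid could help separate the two.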